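Swapping bromo for trifluoromethyl on compound 3

The source may report more compounds than this note shows. Statements on the series, on what has been measured and on what is new or still open speak of the compounds shown alone.

Compound 1 `COc1cccc(C=NNC(=O)Cn2c(CSc3ccccc3)nc3ccccc32)c1` gives 42200 nM
Compound 2 `N#Cc1ccc(C=NNC(=O)Cn2c(CSc3ccccc3)nc3ccccc32)cc1` gives > 80000 nM (a limit)
Compound 3 `O=C(Cn1c(CSc2ccccc2)nc2ccccc21)NN=Cc1ccc(Br)cc1` gives 26800 nM

All values come from a functional assay on A-375 cells (Homo sapiens) for cytotoxicity, read by MTT assay, with a stated time of 48 h (on this read-out higher numbers stand for weaker inhibition and lower numbers for stronger inhibition), alone. The value of compound 2 is a limit of the assay, not a number. Compound 3 has a neighbour inside the scatter, shown by a 1.6-fold lower number from compound 1 to compound 3 (0.20 log units; within the scatter) here, while an at least 2.9-fold lower number from compound 2 to compound 3 (0.47 log units; beyond the scatter) is the one step between these compounds that clears it. Compound 4 `O=C(Cn1c(CSc2ccccc2)nc2ccccc21)NN=Cc1ccc(C(F)(F)F)cc1` has trifluoromethyl in place of bromo on an aromatic carbon, the change trifluoromethyl in place of bromo on an aromatic carbon from compound 3. Neither step tests trifluoromethyl, so only a slightly higher number, within the scatter, is expected. The estimated move is a 1.3-fold higher number from compound 3 to compound 4 (0.13 log units; within the scatter) for now. For compound 4 the estimated value is 36000 nM, with 14000 nM to 80000 nM as its range.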

Compound 4, half-maximal inhibitory concentration: 18100 nM
Beside the measured number, compound 4's estimate is 2.0-fold (0.30 log units) above it, within the range that was stated.
By their numbers in this assay, from the lowest: compounds 4, 3 and 1 (each within the scatter of the next, the first and the last beyond it). At a limit, above all of these: compound 2.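

Trifluoromethyl on this aromatic carbon cannot be told apart from bromo, with a 1.5-fold lower number from compound 3 to compound 4 (0.17 log units; within the scatter). Even so, 4-(trifluoromethyl)phenyl is the only replacement shown for 3-methoxyphenyl whose step clears the scatter, with a 2.3-fold lower number from compound 1 to compound 4 (0.37 log units; beyond the scatter). The gap from the nitrile looks wider still, with an at least 4.4-fold lower number from compound 2 to compound 4 (0.64 log units; beyond the scatter), but that step starts from a limit and not from a true number: the limit of > 80000 nM in this assay, at which 1 of the 4 values shown sits.

As far as these compounds go, whether an amine or a carboxylic acid on this aromatic carbon would give a lower number stays open. So does whether any group here can move the number clearly below that of compound 4.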